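The source may report more compounds than this note shows. Statements on the series, on what has been measured and on what is new or still open speak of the compounds shown alone.

In an ADME assay on HEK293 cells (Homo sapiens) for cytotoxicity, read by resazurin assay, with a stated time of 48 h (a lower number here means that less compound is tolerated, a higher number that more compound is tolerated), compound 1 `O=S(=O)(Nc1ccc(-c2nc3ccccc3o2)cc1)c1ccc(Cl)s1` gives > 100000 nM, and this is a limit of the assay rather than a number. Compound 1 thus stands at the limit of > 100000 nM in this assay, at which 1 of the 3 values shown sits. Compound 2 `O=S(=O)(Nc1ccc2oc(-c3ccccc3)nc2c1)c1ccc(Cl)c(C(F)(F)F)c1` gives 66000 nM in this assay. Compound 3 `Cc1cccc(S(=O)(=O)Nc2ccc3oc(-c4ccccc4)nc3c2)c1` gives 69000 nM in this assay. The numbers for compound 2 and compound 3 lie within the usual scatter of each other, so neither is set apart from the other. Compound 4 `O=S(=O)(Nc1ccc(-c2nc3ccccc3o2)cc1)c1ccc(Cl)c(Cl)c1` has not yet been measured in this assay. It differs from compound 1 in one place: 3,4-dichlorophenyl in place of 5-chlorothiophen-2-yl on a sulfonyl sulfur. For the measured compounds named here, no step between measured compounds is available, so the size of the change is open. All three measured compounds tolerate high concentrations, and the exchange of 5-chlorothiophen-2-yl for 3,4-dichlorophenyl on the sulfonyl sulfur is not expected to move compound 4 beyond the scatter in either direction. Compound 4 is therefore estimated at 90000 nM, with a range from 45000 nM to 200000 nM. The expected step, an at least 1.1-fold lower number from compound 1 to compound 4 (0.04 log units; that floor lies within the scatter), is small.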

Compound 4, half-maximal cytotoxic concentration: > 100000 nM
Compound 4 ended at the assay's limit; the forecaster's own chance of this, stated with the estimate: 40%; middle value at least 1.1-fold (0.04 log units) away from the limit.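

For the compounds shown here, compound 1 and compound 4 both stand at the limit of this assay and no step from the one to the other can be read: the limit of > 100000 nM in this assay, at which 2 of the 4 values shown sit.
The compounds shown leave open how far 3,4-dichlorophenyl in place of 5-chlorothiophen-2-yl on a sulfonyl sulfur moves the tolerated concentration, and in which direction.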